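This account rests on a few compounds, and the source may have more. Where it says the series, first, only, none or still open, it means among the compounds named here.

Compound 3 `CCCc1nc(-c2ccccc2)c(CNCCCN2CCN(c3ccc(C)cc3)CC2)o1` is one of three measured compounds sharing a common core. In an assay on HEK293 cells for inhibition of Voltage-dependent T-type calcium channel subunit alpha-1G (Homo sapiens), read by fluorescence, tested at 10 uM (on this read-out lower numbers stand for less inhibition and higher numbers for more inhibition at the one concentration tested (going by the name of the read-out)), compound 3 gives 53.9%. Compound 1 `CCCc1nc(-c2ccccc2)c(CNCCCN2CCN(c3ccccc3OC)CC2)o1` gives 41% in this assay, and compound 2 `CCCc1nc(-c2ccccc2)c(CNCCCN2CCN(c3ccccc3C(F)(F)F)CC2)o1` gives 45%. The step of a number 12.9 percentage points higher from compound 1 to compound 3 (beyond the scatter) lies beyond the scatter, whereas the step of a number 8.9 percentage points higher from compound 2 to compound 3 (within the scatter) does not, so compound 3 is separated clearly from compound 1 but not from compound 2.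

Compound 4 `CCCc1nc(-c2ccccc2)c(CNCCCN2CCN(c3ccc(C)c(C)c3)CC2)o1` differs from compound 3 in one place: methyl in place of hydrogen on an aromatic carbon. The steps measured so far all alter the aryl group on the amine nitrogen in the ring, and the largest of them, a number 12.9 percentage points higher from compound 1 to compound 3 (beyond the scatter), is only modest, while a number 4 percentage points higher from compound 1 to compound 2 (within the scatter) and a number 8.9 percentage points higher from compound 2 to compound 3 (within the scatter) stay within the scatter. Among the measured compounds shown here, none of them adds a second methyl to the 4-methylphenyl group, so no step on record matches this change directly. Given that every change to this aryl group so far has produced at most a modest step, a small change is expected for compound 4 in this assay, a number 3.1 percentage points higher from compound 3 to compound 4 (within the scatter), which would lie within the scatter. Compound 4 is therefore estimated to give 57% in this assay, with a range from 42% to 72%.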

Compound 4, a percentage reported as inhibition, at one concentration (the size of the read-out at that concentration, not a potency): 54.6%
Estimate against measurement, compound 4: 2.4 percentage points above; low and high end bracket the measured number.
By their numbers in this assay, from the lowest: compounds 1, 2, 3 and 4 (each within the scatter of the next, the first and the last beyond it).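

In this assay, among the compounds shown here, this is the first change that adds to the 4-methylphenyl group instead of replacing the whole aryl group: a methyl on the aromatic carbon ortho to a methyl group and meta to a large group gives a number 0.7 percentage points higher from compound 3 to compound 4 (within the scatter), so 4-methylphenyl and 3,4-dimethylphenyl cannot be told apart in this read-out. The 3,4-dimethylphenyl group stands towards the two ortho-substituted aryl groups much as 4-methylphenyl does, with a number 13.6 percentage points higher from compound 1 to compound 4 (beyond the scatter) separating it from 2-methoxyphenyl, while a number 9.6 percentage points higher from compound 2 to compound 4 (within the scatter) does not separate it from 2-(trifluoromethyl)phenyl. No supporting data are available to explain these results.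

The compounds shown leave open whether a chlorine, a hydroxyl or an ethyl group on this same aromatic carbon would read like the methyl group, or whether a larger group there would produce a step beyond the scatter. They also leave open what a longer chain to the amine nitrogen in the ring would do, since all four compounds differ only in the aryl group.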